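This account rests on a few compounds, and the source may have more. Where it says the series, first, only, none or still open, it means among the compounds named here.

Working notes on the series.

Going by the values given here, compound 2 `C/N=C(\S)NCCCCn1nc(-c2ccccc2)ccc1=O` gives 17.3 mg/kg in a functional assay on the whole organism with Rattus norvegicus as the target (on this read-out lower numbers stand for an effect already at smaller amounts and higher numbers for an effect only at larger amounts of compound), the lowest of the two numbers so far. Among the compounds with values here, its nearest neighbour is compound 1 `CC/N=C(\S)NCCCn1nc(-c2ccccc2)ccc1=O`, which in this assay gives 88.2 mg/kg; the step of a 5.1-fold lower number from compound 1 to compound 2 (0.71 log units; beyond the scatter) is the only measured step in the set, and it changes both the chain and the terminal group at once.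

Compound 3 `C/N=C(/NC#N)NCCCCCn1nc(-c2ccccc2)ccc1=O` differs from compound 2 by a group of 8 heavy atoms (4 carbon, 4 nitrogen; no ring) in place of a group of 5 heavy atoms (2 carbon, 2 nitrogen, 1 sulfur; no ring), on a saturated chain carbon, four bonds along the chain from an aromatic nitrogen. Within the data shown here, no measured step bears directly on this change: the one step recorded, from compound 1 to compound 2, keeps a sulfur-bearing terminal group throughout and alters the chain length together with the group, so it says nothing about exchanging the terminal group for one without sulfur, and nothing about the further lengthening of the chain. Among the measured compounds shown here, with the only precedent a modest step in this assay and no comparable exchange measured, the expectation is that the number stays within the scatter of compound 2, with wide uncertainty in both directions. Compound 3 is therefore estimated at 25 mg/kg, range 8 mg/kg to 80 mg/kg, meaning an expected step of a 1.4-fold higher number from compound 2 to compound 3 (0.16 log units; within the scatter).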

Compound 3, dose for half-maximal effect: 76.2 mg/kg
Compound 3: middle estimate off by 3.0-fold (0.48 log units), on the low side; measured number inside the range.
By their numbers in this assay, from the lowest: compound 2; then compounds 3 and 1 (each within the scatter of the next).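

In this assay, the step of a 4.4-fold higher number from compound 2 to compound 3 (0.64 log units; beyond the scatter) shows that the position four bonds along the chain from an aromatic nitrogen responds to this change, and that a sulfur-free group carrying a nitrile does not keep the number of compound 2. It also runs opposite to the step of a 5.1-fold lower number from compound 1 to compound 2 (0.71 log units; beyond the scatter), so across the two steps, a longer chain does not go with a lower number each time: compound 3, with the longest chain of the three, goes against any such trend. The change alters the chain and the terminal group together, and no measurement on hand accounts for the rise.

Still open, on these data alone, is how much of the step belongs to the chain and how much to the terminal group, a split that the sulfur-bearing group on the chain of compound 3, or the nitrile-bearing group on the chain of compound 2, would settle. Also open, as far as these compounds go, is whether a terminal urea, a simple amine or a still longer chain would give a number near that of compound 2 at 17.3 mg/kg.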